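The source may hold more compounds than are shown below. What is called first, only, known or untested is meant among the compounds shown, and "the series" means these compounds.

Measured so far:
- compound 1, `O=C(Nc1cc(-c2ccccc2)nn1-c1ccccc1)c1ccccn1`, in an assay on CHO cells with metabotropic glutamate receptor 5 (Homo sapiens) as the target (a lower number here means that less compound is needed, a higher number that more compound is needed for the effect), gives 290 nM
- compound 2, `O=C(Nc1cc(-c2ccccc2)nn1-c1ccccc1)c1ccccc1O`, gives > 10000 nM, which is a limit of this assay rather than a number the limit of > 10000 nM in this assay, at which 1 of the 3 values shown sits.
- compound 3, `O=C(Nc1cc(-c2ccccc2)nn1-c1ccccc1)c1ccc(C(F)(F)F)cc1`, gives 19 nM

Compound 3 holds the lowest of the two numbers shown; the nearest is compound 1, and the step between them, a 15-fold lower number from compound 1 to compound 3 (1.18 log units; beyond the scatter), lies beyond the scatter. Compound 4, `O=C(Nc1cc(-c2ccccc2)nn1-c1ccccc1)c1ccsc1`, has not yet been measured. It differs from compound 3 in one place: thiophen-3-yl in place of 4-(trifluoromethyl)phenyl on a carbonyl carbon. The measured steps that bear on this are the two changes already made at the same carbonyl carbon: a 15-fold lower number from compound 1 to compound 3 (1.18 log units; beyond the scatter) and an at least 520-fold lower number from compound 2 to compound 3 (2.72 log units; beyond the scatter). Both show that the group on this carbon moves the number by a large amount, and that the 4-(trifluoromethyl)phenyl group gave the lowest number of the three. Replacing it with the smaller thiophen-3-yl group is therefore expected to raise the number, most likely by a moderate amount, though with wide uncertainty since no ring of this kind has been tried here. For compound 4 the estimate is 150 nM, within a range from 35 nM to 900 nM, which would mean an expected step of a 7.9-fold higher number from compound 3 to compound 4 (0.90 log units; beyond the scatter).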

Compound 4, half-maximal effective concentration: 1800 nM
The estimate for compound 4 lay 12-fold (1.08 log units) below the measured number, outside the stated range (above it).
By their numbers in this assay, from the lowest: compound 3; then compound 1; then compound 4. At a limit, above all of these: compound 2.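

In this assay, among the compounds shown here, this carbonyl carbon proves far less forgiving than the earlier compounds could show, since exchanging one aromatic ring for another gives a 95-fold higher number from compound 3 to compound 4 (1.98 log units; beyond the scatter). The thiophen-3-yl group also falls behind the pyridin-2-yl group, with a 6.2-fold higher number from compound 1 to compound 4 (0.79 log units; beyond the scatter), so among the four compounds, having an aromatic ring here does not by itself give a low number, and compound 4 and compound 2 both go against any such rule. The thiophen-3-yl group still lands on the lower side of the 2-hydroxyphenyl group, with an at least 5.5-fold lower number from compound 2 to compound 4 (0.74 log units; beyond the scatter), but that step rests on a value for compound 2 that is a limit of the assay, not a number: the limit of > 10000 nM in this assay, at which 1 of the 4 values shown sits.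

As far as these compounds go, what stays open is whether the low number of compound 3 belongs to the trifluoromethyl group itself or to the phenyl ring that carries it, a question that a plain phenyl group or a 4-chlorophenyl group on this carbonyl carbon would help to settle. From the compounds shown here alone, it is also open whether a thiophen-2-yl group would behave like the thiophen-3-yl group.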